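Swapping the aniline substituent on a pyrimidine urea

The compounds below may be only part of what the source reports. "The series", "measured", "known", "first", "only" and "open" are said of these compounds alone.

Of the compounds shown here, three sharing one core have been measured in a functional assay on NCI-H520 cells (Homo sapiens) for inhibition, read by MTT assay, with a stated time of 48 h, tested at 10 uM; a higher number here means more inhibition at the concentration tested (going by the name of the read-out), a lower number less inhibition. Compound 1, `COc1cc(NC(=O)Nc2cc(Nc3ccc(C(C)(C)C)cc3)ncn2)cc(OC)c1`, carries a 4-(tert-butyl)phenyl group on the nitrogen that joins the aniline to the core, and in this assay compound 1 gives 17.5%. That is the lowest of the three numbers. Compound 2, `COc1ccc(F)cc1Nc1cc(NC(=O)Nc2c(Cl)cccc2Cl)ncn1`, gives 38.1% in this assay, a number well beyond the scatter above compound 1. Compound 3, `COc1cc(NC(=O)Nc2cc(Nc3cc(C(F)(F)F)ccc3OC)ncn2)cc(OC)c1`, gives 63% in this assay, the largest of the three and furthest from compound 1. No two of these three differ in only one place, so no single change can yet be tied to a shift in the numbers.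

Compound 4, `COc1cc(NC(=O)Nc2cc(Nc3ccc(OC)c(I)c3)ncn2)cc(OC)c1`, has not been measured. It differs from compound 1 in one place: 3-iodo-4-methoxyphenyl in place of 4-(tert-butyl)phenyl on a nitrogen on an aromatic ring. Because compound 3, whose number is the highest of the three, also carries a methoxy group on its aniline ring and gives 63%, compound 4 is expected to sit above compound 1, and the step from compound 1 to compound 4 is estimated as a number 27.5 percentage points higher from compound 1 to compound 4 (beyond the scatter), clearly beyond the scatter. Compound 4 is therefore expected to give about 45%, within a range from 20% to 70%.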

Compound 4, a percentage reported as inhibition, at one concentration (the size of the read-out at that concentration, not a potency): 46.5%
Compound 4: the middle estimate sits 1.5 percentage points below what was measured; low and high end bracket the measured number.
By their numbers in this assay, from the lowest: compound 1; then compounds 2 and 4 (each within the scatter of the next); then compound 3.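

In this assay, among these compounds, the replacement of 4-(tert-butyl)phenyl by 3-iodo-4-methoxyphenyl gives a number 29 percentage points higher from compound 1 to compound 4 (beyond the scatter) and provides the first comparison here that differs in only one place. It shows that the group on this nitrogen on an aromatic ring can move the number beyond the usual scatter, even though the shared core and the other end of the urea stay the same. Both groups hold one six-membered aromatic ring of carbon only, so the change lies in what that ring carries, but nothing measured here accounts for the rise.

The iodine and the methoxy group enter together while the tert-butyl group leaves, so this single step cannot say whether one of them or the combination goes with the higher number. The compounds shown also leave open how the number would respond to quite different groups on this ring, such as an amine or a carboxylic acid, and whether the step would hold with another group at the far end of the urea.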